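Methoxyphenyl placement in the sulfonamide series

The compounds below may be only part of what the source reports. "The series", "measured", "known", "first", "only" and "open" are said of these compounds alone.

Compound 2 `COc1cccc(CNCCCNS(=O)(=O)c2cc(C(F)(F)F)cc(C(F)(F)F)c2)c1` gives 1700 nM in a functional assay on BXPC-3 cells (Homo sapiens) for inhibition, read by MTT assay, with a stated time of 72 h (on this read-out lower numbers stand for stronger inhibition of growth and higher numbers for weaker inhibition of growth), level with compound 1 `O=S(=O)(NCCCCNCc1ccc(Br)cc1)c1cc(C(F)(F)F)cc(C(F)(F)F)c1`, which gives 1700 nM in this assay. Going by the values given here, the single measured step, no change at the digits printed from compound 1 to compound 2 (within the scatter), shows that swapping one benzyl group for another left the read-out unchanged. Compound 3 `COc1ccc(CNCCCNS(=O)(=O)c2cc(C(F)(F)F)cc(C(F)(F)F)c2)cc1` differs from compound 2 by 4-methoxyphenyl in place of 3-methoxyphenyl on a saturated chain carbon bound to an amine nitrogen. Among the compounds with values here, no measured step probes this exact exchange; the one available step was flat, so for compound 3 no shift beyond the scatter is expected, no change at the digits printed from compound 2 to compound 3 (within the scatter). Compound 3 is therefore estimated at 1700 nM in this assay, between 850 nM and 3400 nM.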

Compound 3, concentration for 50% growth inhibition: 1300 nM
Compound 3: the middle estimate sits 1.3-fold (0.12 log units) above what was measured; the measured number falls inside the stated range.
By their numbers in this assay, from the lowest: compounds 3, 1 and 2 (each within the scatter of the next).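

Notes on the methoxyphenyl exchange: in this assay, 4-methoxyphenyl in place of 3-methoxyphenyl on a saturated chain carbon bound to an amine nitrogen gives a 1.3-fold lower number from compound 2 to compound 3 (0.12 log units; within the scatter), so this exchange does not separate the two compounds. The larger exchange of (4-methoxybenzyl)amino for ((4-bromobenzyl)amino)methyl gives a 1.3-fold lower number from compound 1 to compound 3 (0.12 log units; within the scatter), and it is equally flat. No supporting evidence bears on these results.

Still open, on these data alone, is whether a nitrile or a carboxylic acid in place of the methoxy group would move the number beyond the scatter. As far as these compounds go, the effect of a longer chain with the 4-methoxybenzyl group held constant also remains open.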